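The compounds below may be only part of what the source reports. "The series", "measured", "known", "first", "only" and "open" are said of these compounds alone.

Measured so far in a functional assay on MCF7 cells (Homo sapiens) for antiproliferative activity; a higher number here means a weaker inhibitor, a lower number a stronger inhibitor
- compound 1 `CC(C)=CCc1cc(C(=O)Nc2cc3ccc(OCCCNC(C)C)c(C)c3oc2=O)ccc1O` gives 740 nM in this series
- compound 2 `CC(C)=CCc1cc(C(=O)Nc2cc3ccc(OCCCN(C(C)C)C(C)C)c(C)c3oc2=O)ccc1O` gives 1310 nM in this series
- compound 3 `CC(C)=CCc1cc(C(=O)Nc2cc3ccc(OCCCNC(C)(C)C)c(C)c3oc2=O)ccc1O` gives 950 nM in this series

Compound 3 at 950 nM lies within the scatter of both other compounds, so the three values do not separate. Compound 4 `CC(C)=CCc1cc(C(=O)Nc2cc3ccc(OCCCN(C)C(C)(C)C)c(C)c3oc2=O)ccc1O` differs from compound 3 by a single change, (methyl in place of hydrogen on an amine nitrogen), that is, methyl in place of hydrogen on an amine nitrogen.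

The closest measured parallel is the same kind of replacement made with isopropyl, a 1.8-fold higher number from compound 1 to compound 2 (0.25 log units; within the scatter), and it stayed within the scatter. The other two steps, a 1.3-fold higher number from compound 1 to compound 3 (0.11 log units; within the scatter) and a 1.4-fold lower number from compound 2 to compound 3 (0.14 log units; within the scatter), stayed within it as well. For the measured compounds named here, none of the three changes at this amine has gone beyond the scatter in this assay so far.

No step beyond the scatter is therefore expected, only a possible slight drift toward a higher number. The estimated step is a 1.4-fold higher number from compound 3 to compound 4 (0.14 log units; within the scatter), which would remain within the scatter. For compound 4 the expected value is 1300 nM, with an estimated range from 650 nM to 2400 nM for the measurement.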

Compound 4, half-maximal inhibitory concentration: 1140 nM
Beside the measured number, compound 4's estimate is 1.1-fold (0.06 log units) above it, and the stated range covers the measured number.
By their numbers in this assay, from the lowest: compounds 1, 3, 4 and 2 (each within the scatter of the next).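

In this assay, methyl in place of hydrogen on an amine nitrogen, now placed on the (tert-butyl)amino group, gives a step that stays within the scatter (a 1.2-fold higher number from compound 3 to compound 4 (0.08 log units; within the scatter)), as the earlier isopropyl replacement did. Compound 4 also does not separate from the other two compounds (a 1.1-fold lower number from compound 2 to compound 4 (0.06 log units; within the scatter) and a 1.5-fold higher number from compound 1 to compound 4 (0.19 log units; within the scatter)), so all four amine groups shown on this chain remain within the scatter of one another. No supporting measurement is available to explain this result.

The compounds shown leave open whether a dimethylamino group or a cyclic amine such as piperidine or morpholine at this position would give a step beyond the scatter. On these data alone, a longer chain to the amine, or a carboxylic acid in its place, also remains open.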